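This account rests on a few compounds, and the source may have more. Where it says the series, first, only, none or still open, it means among the compounds named here.

Of the compounds shown here, three sharing one core have been tested in a functional assay on HepG2 cells (Homo sapiens) for cytotoxicity, read by MTT assay, with a stated time of 72 h; a lower number here means a stronger inhibitor, a higher number a weaker inhibitor. Compound 1 `COc1ccc2ccc(=O)oc2c1C1=NN(C(N)=O)C(c2ccc(SC)cc2)C1` gives 18 nM, compound 2 `COc1ccc2ccc(=O)oc2c1C1=NN(c2ccccc2)C(c2ccc(SC)cc2)C1` gives 78 nM, and compound 3 `COc1ccc2ccc(=O)oc2c1C1=NN(c2ccccc2)C(c2ccccc2)C1` gives 73 nM. The two cores differ by hydrogen in place of methylsulfanyl on an aromatic carbon, and a 1.1-fold lower number from compound 2 to compound 3 (0.03 log units; within the scatter). Compound 2 and compound 1 differ by carbamoyl in place of phenyl on an amine nitrogen in a ring, and a 4.3-fold lower number from compound 2 to compound 1 (0.64 log units; beyond the scatter).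

Compound 4 `COc1ccc2ccc(=O)oc2c1C1=NN(C(N)=O)C(c2ccccc2)C1` has not been measured. It differs from compound 3 by carbamoyl in place of phenyl on an amine nitrogen in a ring. This is the same kind of change as from compound 2 to compound 1, though the place is not identical: there it was next to the ring atom that bears a 4-(methylsulfanyl)phenyl group, here next to the ring atom that bears a phenyl group. In this assay a similar step is expected, a 4.1-fold lower number from compound 3 to compound 4 (0.61 log units; beyond the scatter), because a 4.3-fold lower number from compound 2 to compound 1 (0.64 log units; beyond the scatter) and the methylsulfanyl change itself hardly moved the number. Compound 4 is therefore estimated at 18 nM, between 8 nM and 45 nM.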

Compound 4, half-maximal inhibitory concentration: 90 nM
For compound 4 the middle estimate is 5.0-fold (0.70 log units) below the measured one; the measured number lies above the stated range.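

In this assay, carbamoyl in place of phenyl on the ring nitrogen gives a 1.2-fold higher number from compound 3 to compound 4 (0.09 log units; within the scatter), so this change does not carry over from the core bearing 4-(methylsulfanyl)phenyl to the core bearing phenyl: the same change on two cores in this assay, a 4.3-fold lower number (0.64 log units; beyond the scatter) from compound 2 to compound 1 and a 1.2-fold higher number (0.09 log units; within the scatter) from compound 3 to compound 4, 5.3-fold (0.73 log units) apart, beyond the scatter of two such steps. Hydrogen in place of methylsulfanyl likewise gives a 5.0-fold higher number from compound 1 to compound 4 (0.70 log units; beyond the scatter) with carbamoyl on the ring nitrogen, so its result depends on the group at that nitrogen: the same change on two cores in this assay, a 1.1-fold lower number (0.03 log units; within the scatter) from compound 2 to compound 3 and a 5.0-fold higher number (0.70 log units; beyond the scatter) from compound 1 to compound 4, 5.3-fold (0.73 log units) apart, beyond the scatter of two such steps. Across these four compounds the two changes do not act independently, but the data do not show why, nor whether this holds beyond this single set of compounds.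

On these data alone, it remains open how other groups on the ring nitrogen, such as acetyl or methyl, would behave. As far as these compounds go, it is equally open whether methoxy or chlorine in place of methylsulfanyl would match it.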